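Chlorophenyl placement on the shared core: compound 2 to compound 3

The compounds below may be only part of what the source reports. "The series", "measured", "known", "first", "only" and "open" are said of these compounds alone.

Of the compounds shown here, two have been measured in an assay on isolated protein for inhibition of DNA topoisomerase 1 (Homo sapiens), with a stated time of 30 min, tested at 100 uM; a lower number here means a weaker effect, a higher number a stronger effect of the compound at the concentration tested. Compound 1 `Oc1ccc(-c2cc(-c3cccc(Cl)c3)nc(-c3ccccn3)c2)cc1` gives 59.4% in this assay. Compound 2 `Oc1ccc(-c2cc(-c3ccsc3)nc(-c3ccccc3Cl)c2)cc1` gives 4.1% in this assay and stands lowest of the two numbers; compound 1 is the nearest, lying higher by a margin that is beyond the usual scatter. The two differ in more than one place, so the gap between them cannot be tied to a single change.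

Compound 3 `Oc1ccc(-c2cc(-c3ccsc3)nc(-c3cccc(Cl)c3)c2)cc1` has not yet been measured. It differs from compound 2 in one place: 3-chlorophenyl in place of 2-chlorophenyl on an aromatic carbon. The change moves the chlorine within the chlorophenyl group on the aromatic carbon next to the ring nitrogen of the shared core, while the thiophen-3-yl and 4-hydroxyphenyl groups stay as in compound 2.

Within the data shown here, no step between compound 2 and a compound differing only in this place is available. The 3-chlorophenyl group is also present in compound 1, whose value in this assay is 59.4%, though on a core with a different second substituent. A modest rise is therefore expected, the step of a number 15.9 percentage points higher from compound 2 to compound 3 (beyond the scatter), with wide uncertainty. For compound 3 the estimate in this assay is 20%, between 0% and 50%.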

Compound 3, a percentage reported as inhibition, at one concentration (the size of the read-out at that concentration, not a potency): 26%
Beside the measured number, compound 3's estimate is 6 percentage points below it, and the stated range covers the measured number.
By their numbers in this assay, from the lowest: compound 2; then compound 3; then compound 1.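

In this assay, a number 21.9 percentage points higher from compound 2 to compound 3 (beyond the scatter) when only the chlorine moves, with 3-chlorophenyl in place of 2-chlorophenyl on the aromatic carbon next to the ring nitrogen. The two groups have the same atoms joined differently, and the thiophen-3-yl and 4-hydroxyphenyl groups stay fixed, so the placement of the chlorine alone shifts the read-out, and the step is modest in size. With the 3-chlorophenyl group held constant, thiophen-3-yl in place of pyridin-2-yl gives a number 33.4 percentage points lower from compound 1 to compound 3 (beyond the scatter), a large step that shows the read-out also depends on this second substituent, while no supporting data on hand explain either step.

On these data alone, it remains open whether the step from 2-chlorophenyl to 3-chlorophenyl would keep its direction and size with pyridin-2-yl in place of thiophen-3-yl, and how a plain phenyl, or a fluorine, a methoxy group or an amine in place of the chlorine, would read at this position. These read-outs come from a single concentration, so the potency of the compounds also stays undefined.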